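Indol-3-yl replacing 4-acetylphenyl on the shared core

The source may hold more compounds than are shown below. What is called first, only, known or untested is meant among the compounds shown, and "the series" means these compounds.

Within the data shown here, compound 3 `COc1cc(-c2ccnc3cc(-c4ccc(C(C)=O)cc4)nn23)cc(OC)c1OC` gives 4390 nM in a functional assay on HCT-116 cells (Homo sapiens) for inhibition, read by CCK-8 assay, with a stated time of 48 h (on this read-out lower numbers stand for stronger inhibition and higher numbers for weaker inhibition), the highest of the three numbers measured so far. Compound 1 `COc1cc(-c2ccnc3cc(-c4ccc(C)cc4)nn23)cc(OC)c1OC` gives 48 nM and compound 2 `COc1cc(-c2ccnc3cc(-c4ccc5cc[nH]c5c4)nn23)cc(OC)c1OC` gives 187 nM; the steps of a 91-fold higher number from compound 1 to compound 3 (1.96 log units; beyond the scatter) and a 23-fold higher number from compound 2 to compound 3 (1.37 log units; beyond the scatter) set compound 3 far above both. Compound 4 `COc1cc(-c2ccnc3cc(-c4c[nH]c5ccccc45)nn23)cc(OC)c1OC` carries the change (1H-indol-3-yl in place of 4-acetylphenyl on an aromatic carbon). The step of a 23-fold higher number from compound 2 to compound 3 (1.37 log units; beyond the scatter) bears most directly, since it shows the 1H-indol-6-yl compound well below the 4-acetylphenyl one, and a 3.9-fold higher number from compound 1 to compound 2 (0.59 log units; beyond the scatter) keeps that indole near the 4-methylphenyl compound. Among the measured compounds shown here, no measured pair shows whether 1H-indol-3-yl behaves like 1H-indol-6-yl. A large step down is expected, a 15-fold lower number from compound 3 to compound 4 (1.17 log units; beyond the scatter). Compound 4 is estimated at 300 nM, within 80 nM to 1500 nM.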

Compound 4, half-maximal inhibitory concentration: 35 nM
Compound 4: the middle estimate sits 8.6-fold (0.93 log units) above what was measured; the measured number lies below the stated range.
By their numbers in this assay, from the lowest: compounds 4 and 1 (each within the scatter of the next); then compound 2; then compound 3.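

At this aromatic carbon of the five-membered ring, the change from 4-acetylphenyl to 1H-indol-3-yl gives a 130-fold lower number from compound 3 to compound 4 (2.10 log units; beyond the scatter) in this assay. The indole's point of attachment also counts, with a 5.3-fold lower number from compound 2 to compound 4 (0.73 log units; beyond the scatter) for 1H-indol-3-yl in place of 1H-indol-6-yl. Set against 4-methylphenyl, 1H-indol-3-yl gives a 1.4-fold lower number from compound 1 to compound 4 (0.14 log units; within the scatter) and so does not separate from it.

Nothing available here accounts for these steps. Open, as far as these compounds go, is how an amine or a carboxylic acid on the phenyl ring would compare with the acetyl of compound 3.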